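The source may report more compounds than this note shows. Statements on the series, on what has been measured and on what is new or still open speak of the compounds shown alone.

Measured so far in a functional assay on RKO cells (Homo sapiens) for inhibition, read by MTT assay, with a stated time of 48 h; a lower number here means a stronger inhibitor, a higher number a weaker inhibitor:
Compound 1 `Cc1nc(N(C)c2ccc([Se]C#N)c(Cl)c2)c2ccccc2n1` gives 11 nM in this assay.
Compound 2 `COc1ccc(N(C)c2nc(C)nc3ccccc23)cc1C(=O)NCC[Se]C#N` gives 1170 nM in this assay.
Compound 3 `Cc1nc(N(C)c2ccc([Se]C#N)c(F)c2)c2ccccc2n1` gives 8 nM in this assay.

Compound 2 stands highest of the three numbers, and its gaps to compound 1 and to compound 3 are both beyond the scatter, so it is the weakest inhibitor of the set. For the measured compounds named here, the only single-point step among the measured compounds is a 1.4-fold lower number from compound 1 to compound 3 (0.14 log units; within the scatter), which lies within the scatter and concerns the halogen on the core shared by compound 1 and compound 3, not the side chain that sets compound 2 apart.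

Compound 4 `COc1ccc(N(C)c2nc(C)nc3ccccc23)cc1OCCC[Se]C#N` differs from compound 2 by a group of 7 heavy atoms (4 carbon, 1 nitrogen, 1 oxygen, 1 selenium; no ring) in place of a group of 8 heavy atoms (4 carbon, 2 nitrogen, 1 oxygen, 1 selenium; no ring), on an aromatic carbon. Going by the values given here, no measured pair shows an exchange of this kind, so there is no step to lean on; the account rests on compound 2 alone. The expected step of a 1.2-fold lower number from compound 2 to compound 4 (0.07 log units; within the scatter) is therefore none beyond the scatter, in no set direction. Compound 4 is estimated at 1000 nM in this assay, with a range from 250 nM to 4000 nM.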

Compound 4, half-maximal inhibitory concentration: 799 nM
Estimate against measurement, compound 4: 1.3-fold (0.10 log units) above; the measured number falls inside the stated range.
By their numbers in this assay, from the lowest: compounds 3 and 1 (each within the scatter of the next); then compounds 4 and 2 (each within the scatter of the next).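

In this assay, the exchange on this aromatic carbon, ortho to a methoxy group, gives a 1.5-fold lower number from compound 2 to compound 4 (0.17 log units; within the scatter) and so leaves the reading unchanged within the usual scatter. For the compounds shown here, the earlier step concerned only a halogen on the shared core; this one is the first to concern the side chain, and it shows that going from a group with 1 hydrogen-bond donor and 1 double bond to one with 0 hydrogen-bond donors and no double bond does not by itself shift the number at this position. Nothing measured here accounts for the two groups reading alike.

The compounds shown leave open whether an amine, a carboxylic acid or a longer chain at this position would move the number beyond the scatter. They also leave open how a chain without selenium would read here.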